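This account rests on a few compounds, and the source may have more. Where it says the series, first, only, none or still open, it means among the compounds named here.

Compound 1 `NC(=O)N/N=C/c1cccc(Cl)c1` was tested in a functional assay on the whole organism with Rattus norvegicus as the target, in the maximal electroshock model, with a stated time of 1 h (a higher number here means that more compound is needed for the effect, a lower number that less compound is needed), where compound 1 gives 24.4 mg/kg. Going by the values given here, this is the only number in hand: compound 2 `NC(=O)N/N=C/c1cccc(Cl)c1Cl` was also made, but in this assay compound 2 gives no result reported, so compound 1 cannot be ranked against any measured companion. Compound 3 `NC(=O)N/N=C/c1ccc(Cl)c(Cl)c1` is the compound still to be measured. It shares the core of compound 1 and differs in one place: chloro in place of hydrogen on an aromatic carbon. Among the compounds with values here, no step between two measured compounds is available to show how such an added chloro group shifts the dose in this assay. With that gap, only a modest change is expected, estimated as a 1.4-fold lower number from compound 1 to compound 3 (0.13 log units; within the scatter), leaning toward a somewhat lower dose but not clearly beyond the usual scatter. Compound 3 is therefore expected to need about 18 mg/kg, within a range from 8 mg/kg to 45 mg/kg.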

Compound 3, dose for half-maximal effect: 20.2 mg/kg
Estimate against measurement, compound 3: 1.1-fold (0.05 log units) below; measured number inside the range.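

Going by these compounds alone, this is the first step that can be read: chloro in place of hydrogen on an aromatic carbon, ortho to a chloro group and para to a group of 6 heavy atoms, gives a 1.2-fold lower number from compound 1 to compound 3 (0.08 log units; within the scatter) in this assay. The doses of the two compounds cannot be told apart, so this position accepts a chloro group with no effect on the dose that stands clear of the usual scatter. No measurement is at hand that could explain this result.

The step to compound 2 cannot be read, as that compound has no number in this assay. As far as these compounds go, whether a different group at this position, such as an amine, a methoxy group or a carboxylic acid, would move the dose beyond the scatter remains open.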